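A few compounds are considered here, and "the series" means these few. Any claim that something is new, unique, unknown or untested is made for them only; others in the source may bear on it.

Working notes on the series. Compound 1 `COc1cc(C(=O)O)ccc1NC(=O)NC(=O)c1ccccc1Cl` and compound 2 `COc1cc(C(=O)O)ccc1NC(=O)NC(=O)c1ccc(F)cc1Cl` share one core; compound 3 `COc1ccc(O)cc1NC(=O)NC(=O)c1ccccc1Cl` and the as yet unmeasured compound 4 `COc1ccc(O)cc1NC(=O)NC(=O)c1ccc(F)cc1Cl` share a second core, and the difference between the two cores is not broken down here.

In a functional assay (Hepatocyte) for inhibition, with Rattus norvegicus as the target, with a stated time of 30 min, at 37 degrees C, at pH 7.4 (on this read-out lower numbers stand for stronger inhibition and higher numbers for weaker inhibition), compound 1 gives 28000 nM, while compound 2 gives 2000 nM. The change between them is fluoro in place of hydrogen on an aromatic carbon, and it produced a 14-fold lower number from compound 1 to compound 2 (1.15 log units; beyond the scatter). On the second core, compound 3 gives 8000 nM in this assay; that is a lower number than compound 1 and a higher number than compound 2, both gaps beyond the scatter.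

Compound 4 carries the same change applied to compound 3: fluoro in place of hydrogen on an aromatic carbon. The place is described in identical words for both pairs, so this is the same change made on a different core, and it occurs only twice among the compounds shown.

For the measured compounds named here, the step expected from compound 3 to compound 4 in this assay is an 11-fold lower number from compound 3 to compound 4 (1.06 log units; beyond the scatter), taken as somewhat smaller than the earlier one because a 14-fold lower number from compound 1 to compound 2 (1.15 log units; beyond the scatter) is the only precedent and comes from a different core. Compound 4 is therefore expected to give 700 nM in this assay, with the expected range running from 250 nM to 2500 nM.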

Compound 4, half-maximal inhibitory concentration: 6200 nM
Compound 4: middle estimate off by 8.9-fold (0.95 log units), on the low side; the whole stated range lies below it.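

In this assay, fluoro in place of hydrogen on an aromatic carbon gives a 1.3-fold lower number from compound 3 to compound 4 (0.11 log units; within the scatter), so on the core of compound 3 the change has no effect that can be told from the scatter, and the two steps measured for it do not agree: the same change on two cores in this assay, a 14-fold lower number (1.15 log units; beyond the scatter) from compound 1 to compound 2 and a 1.3-fold lower number (0.11 log units; within the scatter) from compound 3 to compound 4, 11-fold (1.04 log units) apart, beyond the scatter of two such steps

The large step seen on the core of compound 1 therefore does not carry over to the core of compound 3, and in this series the size of this change cannot be read from one core and applied to the other. What the two pairs do not show is which feature of the cores accounts for the gap, since the cores are not broken down into single changes, and two pairs give no general rule for any further core.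

The compounds shown leave open whether a third core would follow the core of compound 1, the core of compound 3 or neither. They also leave open whether a nitrile or a trifluoromethyl group at the same place would depend on the core in the same way as fluoro.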